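A few compounds are considered here, and "the series" means these few. Any claim that something is new, unique, unknown or untested is made for them only; others in the source may bear on it.

Measured compounds:
- Compound 1, `COc1cc2c(Nc3ccc(C#N)cc3)ncnc2cc1OCCCN1CCCCC1`: in a functional assay on MCF7 cells (Homo sapiens) for antiproliferative activity, read by MTT assay, with a stated time of 72 h (on this read-out lower numbers stand for stronger inhibition and higher numbers for weaker inhibition), compound 1 gives 35100 nM.
- Compound 2, `COc1cc2c(Nc3ccc(C#N)cc3)ncnc2cc1OCCCN1CCC(O)CC1`: in this assay compound 2 reaches only the limit of > 100000 nM, a boundary of the measurement rather than a number.
- Compound 3, `CCOC(=O)C1CCN(CCCOc2cc3ncnc(Nc4ccc(C#N)cc4)c3cc2OC)CC1`: in this assay compound 3 gives 34900 nM.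

Among the two numbers shown, compound 3 has the lowest, but the step between the two is a 1.0-fold lower number from compound 1 to compound 3 (0.00 log units; within the scatter), which means the two cannot be told apart. Going by the values given here, the one change that stood out at this position is an at least 2.8-fold higher number from compound 1 to compound 2 (0.45 log units; beyond the scatter), and likewise an at least 2.8-fold lower number from compound 2 to compound 3 (0.45 log units; beyond the scatter); both involve the hydroxy group, which also sits at the limit of > 100000 nM in this assay, at which 1 of the 3 values shown sits.

Compound 4, `COc1cc2c(Nc3ccc(C#N)cc3)ncnc2cc1OCCCN1CCC(c2ccccc2)CC1`, differs from compound 3 in one place: phenyl in place of ethoxycarbonyl on a saturated ring carbon. Among the compounds with values here, no measured step exchanges an ethoxycarbonyl for a phenyl, so the expectation rests only on the observation that ethoxycarbonyl and hydrogen at this saturated ring carbon gave numbers within the scatter of each other, while only the hydroxy group moved the value. In this assay compound 4 is therefore expected to sit near compound 3, with the step of a 1.2-fold lower number from compound 3 to compound 4 (0.07 log units; within the scatter), not clearly beyond the scatter in either direction. Compound 4 is estimated at 30000 nM, with a plausible range from 8000 nM to 100000 nM.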

Compound 4, half-maximal inhibitory concentration: 9800 nM
The estimate for compound 4 lay 3.1-fold (0.49 log units) above the measured number, and the stated range covers the measured number.
By their numbers in this assay, from the lowest: compound 4; then compounds 3 and 1 (each within the scatter of the next). At a limit, above all of these: compound 2.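

At this saturated ring carbon, three ring bonds from the ring nitrogen, hydrogen and ethoxycarbonyl could not be told apart, so phenyl is the first group shown to improve on either of them in this assay, with a 3.6-fold lower number from compound 1 to compound 4 (0.55 log units; beyond the scatter) and a 3.6-fold lower number from compound 3 to compound 4 (0.55 log units; beyond the scatter). The position can therefore move the number in both directions, and compound 4 is the strongest of the four, with an at least 10-fold lower number from compound 2 to compound 4 (1.00 log units; beyond the scatter) marking the full span between the phenyl and hydroxy groups. That span has an open upper end, as compound 2 gives a limit and not a number: the limit of > 100000 nM in this assay, at which 1 of the 4 values shown sits.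

On these data alone, whether the gain depends on phenyl being aromatic remains open, and a cyclohexyl group at the same carbon would help to separate the ring itself from its aromatic character. Also open, as far as these compounds go, is how a benzyl group, a carboxylic acid or a primary amine at this carbon would compare with phenyl, and so how far the trend set by these four compounds extends.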